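This account rests on a few compounds, and the source may have more. Where it says the series, first, only, none or still open, it means among the compounds named here.

Measured compounds:
compound 1 `O=C(CCCCCCc1ccccc1C(=O)O)c1ncc(-c2ccccn2)o1` — > 600 nM in an assay for inhibition of Fatty-acid amide hydrolase 1 (Rattus norvegicus); a lower number here means a stronger inhibitor, a higher number a weaker inhibitor
compound 2 `O=C(CCCCCCc1ccccn1)c1ncc(-c2ccccn2)o1` — 120 nM
compound 3 `O=C(CCCCCCc1cccnc1)c1ncc(-c2ccccn2)o1` — 32 nM.

Compound 1 gives only a limit of this assay (the limit of > 600 nM in this assay, at which 1 of the 3 values shown sits). Among the two numbers that are not limits, compound 3 gives the lowest value, and its nearest neighbour is compound 2, with the step of a 3.8-fold lower number from compound 2 to compound 3 (0.57 log units; beyond the scatter). The step from the limit of compound 1 to compound 3 reads an at least 18-fold lower number from compound 1 to compound 3 (1.27 log units; beyond the scatter), and from compound 1 to compound 2 an at least 5.0-fold lower number from compound 1 to compound 2 (0.69 log units; beyond the scatter).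

The unmeasured compound 4 `O=C(CCCCCCc1ccccc1Cl)c1ncc(-c2ccccn2)o1` differs from compound 3 by 2-chlorophenyl in place of pyridin-3-yl on a saturated chain carbon, six bonds along the chain from a carbonyl carbon. Going by the values given here, none of the measured steps makes this same exchange; they show only that the ring on this chain carbon changes this assay by modest to large amounts, and that a 2-carboxyphenyl ring there gives a weak compound. Since 2-chlorophenyl is not 2-carboxyphenyl, and the three measured rings give no direction for it, the expected step is taken as small, with a wide range: compound 4 is estimated at 25 nM (6 nM to 110 nM), an expected step of a 1.3-fold lower number from compound 3 to compound 4 (0.11 log units; within the scatter).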

Compound 4, inhibition constant: 1.9 nM
Beside the measured number, compound 4's estimate is 13-fold (1.12 log units) above it, outside the stated range (below it).
By their numbers in this assay, from the lowest: compound 4; then compound 3; then compound 2. At a limit, above all of these: compound 1.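

In this assay, 2-chlorophenyl on this saturated chain carbon gives the strongest inhibitor of the four, with a 17-fold lower number from compound 3 to compound 4 (1.23 log units; beyond the scatter) and a 63-fold lower number from compound 2 to compound 4 (1.80 log units; beyond the scatter). Going by these compounds alone, the earlier compounds had compared only two pyridine rings and a limit for 2-carboxyphenyl, and compound 4 now shows that a ring of carbon only can stand here and outdo both pyridin-2-yl and pyridin-3-yl. On the same ring, chloro in place of carboxy gives an at least 310-fold lower number from compound 1 to compound 4 (2.49 log units; beyond the scatter), a step that starts from a limit of the assay for compound 1, so its true size is unknown: the limit of > 600 nM in this assay, at which 1 of the 4 values shown sits.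

The compounds shown leave open whether the chlorine or the carbon-only ring accounts for this step, a question that an unsubstituted phenyl ring at this place would address. They also leave open whether a methoxy group or bromine could take the place of the chlorine.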